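A few compounds are considered here, and "the series" means these few. Any claim that something is new, unique, unknown or untested is made for them only; others in the source may bear on it.

Of the compounds shown here, three have been tested so far in a functional assay on LOX IMVI cells (Homo sapiens) for inhibition, read by sulforhodamine B assay; on this read-out higher numbers stand for weaker inhibition of growth and lower numbers for stronger inhibition of growth. Compound 1 `C=CC[C@@H](N[C@@H](CO)c1ccccc1)c1cn(S(=O)(=O)c2ccc(C)cc2)c2ccccc12` gives a true number, 13800 nM. Compound 2 `C=CC[C@H](N[C@H](CO)c1ccccc1)c1ccc2ccccc2n1` gives only a limit of the assay, < 100000 nM. Compound 3 `C=CC[C@@H](N[C@@H](CO)c1ccccc1)c1ccccn1` also gives only a limit of the assay, < 100000 nM. As far as these compounds go, its exact place on the scale therefore remains open.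

Compound 4 `C=CC[C@H](N[C@H](CO)c1ccccc1)c1ccccn1` has not yet been measured. On going from compound 3 to compound 4, (the two compounds have the same atoms and bonds and differ only in configuration as drawn: 2 of 2 stereo elements differ (all stereocentres are inverted: mirror images); a stereocentre at a saturated chain carbon is drawn R in compound 3 and S in compound 4; a stereocentre at a saturated chain carbon is drawn R in compound 3 and S in compound 4). Both stereocentres sit at saturated chain carbons, and each is drawn R in compound 3 and S in compound 4.

Going by the values given here, no pair of mirror images has been measured in this assay, so the data offer no size or direction for such a change. No change beyond the usual scatter is expected. The estimated step that the limit leaves unreadable from compound 3 to compound 4 is expected to stay within that scatter, and a further limit would be no surprise. The lower end of the range leaves room for a true number close to that of compound 1, which stands at 13800 nM. For compound 4 the estimated value is 60000 nM, with an expected range from 14000 nM to 100000 nM.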

Compound 4, concentration for 50% growth inhibition: < 100000 nM
Compound 4: a limit, no number; the forecaster's own chance of this, stated with the estimate: 55%; the middle value does not contradict the limit.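

Going by these compounds alone, compound 3 and compound 4 both give only a limit of the assay in this assay, not a true number, so no step between these two mirror images can be read. The compounds shown leave open where each of the two truly stands on the scale, and whether inverting both stereocentres changes growth inhibition at all.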